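Terminal Aryl Exchange on a Bile Acid Receptor Ligand

The source may hold more compounds than are shown below. What is called first, only, known or untested is meant among the compounds shown, and "the series" means these compounds.

Measured compounds:
compound 1 `COC(=O)/C=C/c1cccc(N(Cc2ccc(/C=C/c3scnc3C)cc2)C(=O)C2CCCCC2)c1` — 227 nM
compound 2 `COC/C=C/c1ccc(CN(C(=O)C2CCCCC2)c2cccc(/C=C/C(=O)OC)c2)cc1` — 233 nM
compound 3 `COC(=O)/C=C/c1cccc(N(Cc2ccc(-c3cccc(C(C)=O)c3)cc2)C(=O)C2CCCCC2)c1` — 227 nM

All three compounds share the same core and were tested in an assay on isolated protein with Bile acid receptor (Homo sapiens) as the target; on this read-out higher numbers stand for an effect only at larger amounts of compound and lower numbers for an effect already at smaller amounts. In this assay compound 1 gives 227 nM, compound 2 gives 233 nM and compound 3 gives 227 nM. Compound 3 stands level with compound 1, and the two together hold the lowest numbers of the set, yet the spread to compound 2 is also within the scatter (a 1.0-fold lower number from compound 2 to compound 3 (0.01 log units; within the scatter)), so the three values are indistinguishable.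

Compound 4 `COC(=O)/C=C/c1cccc(N(Cc2ccc(/C=C/c3ccc(OC)cc3)cc2)C(=O)C2CCCCC2)c1` is the next variation at the same aromatic carbon: 2-(4-methoxyphenyl)ethenyl in place of 3-acetylphenyl on an aromatic carbon. Within the data shown here, the steps that bear on this exchange all sit on that carbon. From compound 1 to compound 3 the number is unchanged (no change at the digits printed from compound 1 to compound 3 (within the scatter)), and from compound 1 to compound 2 it is likewise flat (a 1.0-fold higher number from compound 1 to compound 2 (0.01 log units; within the scatter)). Three rather different groups at this position have thus left this assay untouched, which suggests the read-out is insensitive to what sits there.

For compound 4 the expected step is therefore none beyond the scatter, a 1.0-fold higher number from compound 3 to compound 4 (0.01 log units; within the scatter). Compound 4 is estimated at 230 nM, with a likely range from 100 nM to 520 nM.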

Compound 4, half-maximal effective concentration: 208 nM
Compound 4: the middle estimate sits 1.1-fold (0.04 log units) above what was measured; the range from low to high includes it.
By their numbers in this assay, from the lowest: compounds 4, 1, 3 and 2 (each within the scatter of the next).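

In this assay, 2-(4-methoxyphenyl)ethenyl in place of 3-acetylphenyl, on an aromatic carbon para to a large group, gives a small step (a 1.1-fold lower number from compound 3 to compound 4 (0.04 log units; within the scatter)), so a fourth group at this place also leaves the read-out within the scatter. The two exchanges at the end of the ethenyl chain add to this: 4-methoxyphenyl in place of methoxymethyl gives one step (a 1.1-fold lower number from compound 2 to compound 4 (0.05 log units; within the scatter)), and 4-methoxyphenyl in place of 4-methyl-1,3-thiazol-5-yl gives another (a 1.1-fold lower number from compound 1 to compound 4 (0.04 log units; within the scatter)), so across these four compounds a six-membered aromatic ring of carbon only at the chain end reads the same as the earlier end groups. Nothing in the data shown offers an explanation for this flat picture.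

On these data alone, what stays open is whether any group at this aromatic carbon can move the number beyond the scatter, since all four compounds fall within it of one another. A carboxylic acid or an amine on the terminal ring would test this, and the compounds shown say nothing about changes elsewhere on the shared core.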